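From compound 2 to compound 3: one added methoxy

A few compounds are considered here, and "the series" means these few. Any claim that something is new, unique, unknown or untested is made for them only; others in the source may bear on it.

In a functional assay on DU-145 cells (Homo sapiens) for cytotoxicity, read by MTT assay, with a stated time of 48 h (a lower number here means a stronger inhibitor, a higher number a weaker inhibitor), compound 2 (`COc1ccc(/C=C/C(=O)/C=C/c2cc3ccccc3nc2Oc2ccccc2)cc1OC`) stands at > 10000 nM, which is a limit of the assay and not a number. Among the compounds with values here, compound 1 (`COc1cc(OC)c(OC)cc1/C=C/C(=O)/C=C/c1cc2ccccc2nc1Cl`) gives 3990 nM in this assay, the only exact value so far. Compound 3 (`COc1cc(OC)c(OC)cc1/C=C/C(=O)/C=C/c1cc2ccccc2nc1Oc1ccccc1`) has methoxy in place of hydrogen on an aromatic carbon of compound 2: methoxy in place of hydrogen on an aromatic carbon. Within the data shown here, no measured step covers this change, and the limit on compound 2 leaves its true starting point open. A small strengthening in this assay is expected, or none beyond the scatter: an at least 1.2-fold lower number from compound 2 to compound 3 (0.09 log units; that floor lies within the scatter). For compound 3 the estimated value is 8000 nM, with an expected range of 3000 nM to 25000 nM.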

Compound 3, half-maximal inhibitory concentration: 9220 nM
The estimate for compound 3 lay 1.2-fold (0.06 log units) below the measured number; the range from low to high includes it.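

In this assay the methoxy on this aromatic carbon, ortho to a large group, gives an at least 1.0-fold lower number from compound 2 to compound 3 (0.03 log units; that floor lies within the scatter) and so shows no strengthening beyond the scatter. Going by these compounds, the true size of this step stays unknown because compound 2 sits at a limit of the assay and not at a number: the limit of > 10000 nM in this assay, at which 1 of the 3 values shown sits. Within the data shown here, at the other position, phenoxy in place of chloro gives a 2.3-fold higher number from compound 1 to compound 3 (0.36 log units; beyond the scatter) as the only step that clears the scatter.

The compounds shown leave open how the methoxy step reads with chloro in place of phenoxy. On these data alone, whether an amine at the phenoxy position would lower the number also remains open.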